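Swapping the group on the aromatic nitrogen once more

The source may hold more compounds than are shown below. What is called first, only, known or untested is meant among the compounds shown, and "the series" means these compounds.

In a functional assay on Hep 3B2 cells (Homo sapiens) for inhibition, read by sulforhodamine B assay, with a stated time of 72 h (a higher number here means a weaker inhibitor, a lower number a stronger inhibitor), compound 1 `C[C@H](Nc1ncnc2[nH]cnc12)c1nn(-c2cccnc2)c2cc(F)ccc12` gives 34500 nM and compound 2 `C[C@H](Nc1ncnc2[nH]cnc12)c1nn(-c2cccc(S(C)(=O)=O)c2)c2cc(F)ccc12` gives 13000 nM, so compound 2 holds the lower of the two numbers. Among the compounds with values here, the only measured step, a 2.7-fold lower number from compound 1 to compound 2 (0.42 log units; beyond the scatter), accompanies 3-(methylsulfonyl)phenyl in place of pyridin-3-yl on an aromatic nitrogen. Compound 3 `C[C@H](Nc1ncnc2[nH]cnc12)c1nn(-c2cc(F)cc(F)c2)c2cc(F)ccc12` keeps the shared core but carries 3,5-difluorophenyl in place of 3-(methylsulfonyl)phenyl on that same aromatic nitrogen (3,5-difluorophenyl in place of 3-(methylsulfonyl)phenyl on an aromatic nitrogen). Within the data shown here, no measured compound yet carries this group, so the direction remains open. Given the modest size of a 2.7-fold lower number from compound 1 to compound 2 (0.42 log units; beyond the scatter), only a small move is expected, perhaps none beyond the scatter. The expected change is a 1.1-fold higher number from compound 2 to compound 3 (0.03 log units; within the scatter) on this estimate. Compound 3 is estimated at 14000 nM with an expected range from 5000 nM to 35000 nM in this assay when measured.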

Compound 3, half-maximal inhibitory concentration: > 40000 nM
Compound 3 gave a limit, no number; the forecaster's own chance of this, stated with the estimate: 10%; middle value at least 2.8-fold (0.45 log units) from the limit.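

In this assay compound 3 returns a limit and not a number: the limit of > 40000 nM in this assay, at which 1 of the 3 values shown sits. Even so, the position on the aromatic nitrogen proves sensitive to this swap, which keeps a six-membered aromatic ring of carbon only and exchanges methylsulfonyl for two fluorines, with an at least 3.0-fold higher number from compound 2 to compound 3 (0.48 log units; beyond the scatter) as the reading, so 3-(methylsulfonyl)phenyl remains the best group of the three against 3,5-difluorophenyl. Against pyridin-3-yl the reading is an at least 1.1-fold higher number from compound 1 to compound 3 (0.06 log units; that floor lies within the scatter) and this floor does not order the two groups, so 3,5-difluorophenyl and pyridin-3-yl cannot be told apart here.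

As far as these compounds go, how far compound 3 lies beyond its limit stays unknown, and with one swap it cannot be said whether the methylsulfonyl group's hydrogen-bond acceptors or the fluorines matter more. An amine, a carboxylic acid or an unsubstituted phenyl at this position remains an open question.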